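Carbonyl substituent change from compound 2 to compound 3

The source may report more compounds than this note shows. Statements on the series, on what has been measured and on what is new or still open speak of the compounds shown alone.

- Compound 1 `O=C(N[C@H](/C=C/S(=O)(=O)c1ccccc1)CCc1ccccc1)c1cccc2nccnc12` gives 39600 nM in an ADME assay on HepG2 cells (Homo sapiens) for cytotoxicity (on this read-out lower numbers stand for higher toxicity in this test and higher numbers for lower toxicity in this test), as a measured number
- Compound 2 `O=C(N[C@H](/C=C/S(=O)(=O)c1ccccc1)CCc1ccccc1)c1cccc2c1NCCC2` gives > 160000 nM in this assay as a limit, not a number

Compound 2 stands at the limit of > 160000 nM in this assay, at which 1 of the 2 values shown sits, and has no exact number. Compound 3 `O=C(N[C@H](/C=C/S(=O)(=O)c1ccccc1)CCc1ccccc1)[C@@H]1CSCN1` carries 1,3-thiazolidin-4-yl in place of 1,2,3,4-tetrahydroquinolin-8-yl on a carbonyl carbon at the same carbonyl carbon. Among the compounds with values here, the only measured step at this place is an at least 4.0-fold higher number from compound 1 to compound 2 (0.60 log units; beyond the scatter) and it points to steps of modest size or more here. A step toward a lower number is expected, estimated as an at least 2.0-fold lower number from compound 2 to compound 3 (0.30 log units; that floor lies within the scatter) on this single precedent. Compound 3 is estimated at 80000 nM with an expected range of 25000 nM to 200000 nM in this assay for now.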

Compound 3, half-maximal cytotoxic concentration: 77800 nM
Estimate against measurement, compound 3: 1.0-fold (0.01 log units) above; the measured number falls inside the stated range.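

In this assay, 1,3-thiazolidin-4-yl on this carbonyl carbon gives an at least 2.0-fold lower number from compound 2 to compound 3 (0.31 log units; beyond the scatter), so compound 2 now stands apart from two different groups at this place, not one. Against quinoxalin-5-yl the same group gives a 2.0-fold higher number from compound 1 to compound 3 (0.29 log units; within the scatter), which leaves compound 1 and compound 3 not separable here, although one carries a five-membered non-aromatic ring and the other an aromatic group. Compound 2 has no exact number, so its steps are open-ended: the limit of > 160000 nM in this assay, at which 1 of the 3 values shown sits.

Open, on these data alone, is whether the number at this carbonyl carbon depends on a ring at all, as a simple phenyl group or an open-chain amine here could tell.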